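The source may report more compounds than this note shows. Statements on the series, on what has been measured and on what is new or still open speak of the compounds shown alone.

compound 1 `N#Cc1cc(C(=O)N2CC=CC2)cc(C(F)(F)F)c1O`: 83%
compound 2 `CCCc1cc(C(=O)N2CC=CC2)cc(C#N)c1O`: 70%

Going by the values given here, in an assay on isolated protein for inhibition of solute carrier family 22 member 12 (Homo sapiens), tested at 3 uM (a higher number here means more inhibition at the concentration tested (going by the name of the read-out), a lower number less inhibition), compound 1 gives 83%, the highest of the two numbers measured so far. Compound 2 gives 70%, and the step of a number 13 percentage points lower from compound 1 to compound 2 (beyond the scatter) shows that swapping the group on the aromatic carbon lowered inhibition. Compound 3 `CC1=CCN(C(=O)c2cc(C#N)c(O)c(C(F)(F)F)c2)C1` differs from compound 1 by methyl in place of hydrogen on a double-bonded ring carbon. Among the compounds with values here, the only measured step concerns the aromatic ring, not the five-membered ring, so it offers no direct guide here, and no step of this kind has been measured. A change of a number 3 percentage points lower from compound 1 to compound 3 (within the scatter) is therefore expected, within the scatter. Compound 3 is estimated at 80%, between 64% and 92%.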

Compound 3, a percentage reported as inhibition, at one concentration (the size of the read-out at that concentration, not a potency): 88%
Beside the measured number, compound 3's estimate is 8 percentage points below it; measured number inside the range.
By their numbers in this assay, from the lowest: compound 2; then compounds 1 and 3 (each within the scatter of the next).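

In this assay, methyl in place of hydrogen on a double-bonded ring carbon gives a number 5 percentage points higher from compound 1 to compound 3 (within the scatter), so compound 1 and compound 3 cannot be told apart. The five-membered ring can therefore carry this one added carbon with no measurable loss of inhibition, whereas the earlier step concerned only a group on an aromatic carbon. Nothing available explains this result. From the compounds shown here alone, whether an ethyl group, a longer chain or an amine on the same ring carbon would also keep inhibition remains open. So does whether the methyl would give the same result alongside propyl on the aromatic carbon.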